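The source may hold more compounds than are shown below. What is called first, only, known or untested is meant among the compounds shown, and "the series" means these compounds.

Working notes on the series. Among the compounds with values here, in an assay on HEK293 cells for inhibition of Voltage-dependent N-type calcium channel subunit alpha-1B (Homo sapiens), read by fluorescence and calcium flux, with a stated time of 5 min (on this read-out lower numbers stand for stronger inhibition and higher numbers for weaker inhibition), compound 1 `COc1ccccc1-n1nc([C@@H]2CCO[C@@H](C(C)C)C2)cc1-c1ccc(Cl)cc1` gives 20 nM, the highest of the three numbers so far. Within the data shown here, compound 2 `CCOc1ccc(-c2cc(C3CC(C)(C)OC(C)(C)C3)nn2-c2ccccc2OC)cc1` gives 2 nM and compound 3 `COc1ccccc1-n1nc(C2CC(C)(C)OC(C)(C)C2)cc1-c1csc(Cl)c1` gives 6 nM; both carry the same oxane group, and the one measured step between them, a 3.0-fold higher number from compound 2 to compound 3 (0.48 log units; beyond the scatter), concerns the aryl group on the shared core and not the oxane. Among the measured compounds shown here, compound 1 and compound 3 differ in two places at once, so their values show only that compound 1 sits higher.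

Compound 4 `COc1ccccc1-n1nc(C2C[C@H](C)O[C@@H](C)C2)cc1-c1ccc(Cl)cc1` is next: 2,6-dimethyloxan-4-yl in place of 2-isopropyloxan-4-yl on an aromatic carbon. For the measured compounds named here, no measured step touches this position, so the expectation for compound 4 rests on the gap between compound 1 and the two lower compounds alone, both of which carry a more substituted oxane. Compound 4 is therefore expected to sit near compound 1 or somewhat lower, with a step of a 1.7-fold lower number from compound 1 to compound 4 (0.22 log units; within the scatter) that may stay within the scatter. The estimate for compound 4 in this assay is 12 nM, within 4 nM to 40 nM.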

Compound 4, half-maximal inhibitory concentration: 2 nM
Compound 4: the middle estimate sits 6.0-fold (0.78 log units) above what was measured; measured number below the stated range.
By their numbers in this assay, from the lowest: compounds 2 and 4 (each within the scatter of the next); then compound 3; then compound 1.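

In this assay, the oxane substituent itself moves the number: with the rest of the core of compound 1 unchanged, 2,6-dimethyloxan-4-yl in place of 2-isopropyloxan-4-yl gives a 10-fold lower number from compound 1 to compound 4 (1.00 log units; beyond the scatter). Within the data shown here, the earlier measured step concerned only the aryl group, so this is the first single-place change read at this aromatic carbon. The entering and leaving groups share the same six-membered ring, the same hydrogen-bond counts and the same number of defined stereocentres, so the step separates two oxane substitution patterns, and nothing available here bears on why the number moves.

The compounds shown leave open whether one methyl group on the oxane would serve as well as two, and how the other stereoisomers of the 2,6-dimethyloxan-4-yl group compare. They also leave open how a piperidine ring, carrying an amine nitrogen in place of the ring oxygen, would read at this position.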